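Sulfonyl aryl variation in the fluoroquinoline piperidine series

This account rests on a few compounds, and the source may have more. Where it says the series, first, only, none or still open, it means among the compounds named here.

Compound 3 `CC1CCN(c2c(S(=O)(=O)c3cccc(F)c3)cnc3c(F)cccc23)CC1` gives 62% in an assay on isolated protein for displacement of a labelled ligand from metabotropic glutamate receptor 5 (Homo sapiens), with a stated time of 60 min, tested at 1 uM (on this read-out lower numbers stand for less inhibition and higher numbers for more inhibition at the one concentration tested (going by the name of the read-out)), which puts it second of the three measured compounds: compound 2 `CC1CCN(c2c(S(=O)(=O)c3ccc(Cl)c(Cl)c3)cnc3c(F)cccc23)CC1` stands higher with 95%, compound 1 `CC1CCN(c2c(S(=O)(=O)c3cc(F)cc(F)c3)cnc3c(F)cccc23)CC1` lowest with 9%. The step to compound 4 `CC1CCN(c2c(S(=O)(=O)c3ccc(F)c(Cl)c3)cnc3c(F)cccc23)CC1` is 3-chloro-4-fluorophenyl in place of 3-fluorophenyl on a sulfonyl sulfur. Within the data shown here, two measured steps bear on it. The most direct is a number 33 percentage points lower from compound 2 to compound 3 (beyond the scatter), which shows that the 3,4-dichlorophenyl on the sulfonyl sulfur carries much more inhibition than the 3-fluorophenyl. The step of a number 86 percentage points higher from compound 1 to compound 2 (beyond the scatter) points the same way, the 3,4-dichlorophenyl far above the 3,5-difluorophenyl. The 3-chloro-4-fluorophenyl of compound 4 shares the chloro of the 3,4-dichlorophenyl and the fluoro of the 3-fluorophenyl, so compound 4 is expected to sit between compound 3 and compound 2, as an upward step of a number 18 percentage points higher from compound 3 to compound 4 (beyond the scatter) beyond the scatter. Compound 4 is therefore estimated at 80% in this assay, with a range from 65% to 95%. The support rests on three compounds only.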

Compound 4, a percentage reported as inhibition, at one concentration (the size of the read-out at that concentration, not a potency): 95%
Compound 4: the middle estimate sits 15 percentage points below what was measured; measured number inside the range.
By their numbers in this assay, from the lowest: compound 1; then compound 3; then compounds 2 and 4 (each within the scatter of the next).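

In this assay, 3-chloro-4-fluorophenyl in place of 3-fluorophenyl on the sulfonyl sulfur gives a number 33 percentage points higher from compound 3 to compound 4 (beyond the scatter), and against the 3,5-difluorophenyl it gives a number 86 percentage points higher from compound 1 to compound 4 (beyond the scatter). Fluoro in place of chloro on an aromatic carbon of the 3,4-dichlorophenyl gives no change at the digits printed from compound 2 to compound 4 (within the scatter), so at this position a second chloro is not required for this level of inhibition, and a chloro together with a fluoro serves as well as two chloro groups at the one concentration tested. No measurement shown explains these steps.

A single concentration does not tell whether compound 2 and compound 4 differ in potency. From the compounds shown here alone, whether 3-chlorophenyl alone holds this level remains open, as does the effect of a methoxy or trifluoromethyl group in place of the chloro.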